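Replacing 4-methoxyphenyl with 2-phenylethenyl on the shared core

A few compounds are considered here, and "the series" means these few. Any claim that something is new, unique, unknown or untested is made for them only; others in the source may bear on it.

Measured in a functional assay on LN-229 cells (Homo sapiens) for antiproliferative activity, with a stated time of 72 h; on this read-out lower numbers stand for stronger inhibition and higher numbers for weaker inhibition:
- compound 1 `Nc1ncnn2c([C@@H]3O[C@H](CO)[C@@H](O)[C@H]3O)cc(C#Cc3cccs3)c12`: > 100000 nM, a limit of the assay
- compound 2 `Nc1ncnn2c([C@@H]3O[C@H](CO)[C@@H](O)[C@H]3O)cc(-c3ccccc3)c12`: 75100 nM
- compound 3 `COc1ccc(-c2cc([C@@H]3O[C@H](CO)[C@@H](O)[C@H]3O)n3ncnc(N)c23)cc1`: 40300 nM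

Compound 3 sits within the scatter of compound 2, with a 1.9-fold lower number from compound 2 to compound 3 (0.27 log units; within the scatter). Against the limit of compound 1, the reading is an at least 2.4-fold lower number from compound 1 to compound 3 (0.39 log units; beyond the scatter).

Compound 4 `Nc1ncnn2c([C@@H]3O[C@H](CO)[C@@H](O)[C@H]3O)cc(/C=C/c3ccccc3)c12` is not yet measured. The change from compound 3 is 2-phenylethenyl in place of 4-methoxyphenyl on an aromatic carbon.

Two kinds of step bear on it. Removing the methoxy alone, as in the step between compound 2 and compound 3, stays within the scatter. Like the 2-(thiophen-2-yl)ethynyl of compound 1, 2-phenylethenyl sets its ring apart from the core by an unsaturated link. Leaving that group gave an at least 1.3-fold lower number from compound 1 to compound 2 (0.12 log units; that floor lies within the scatter) and an at least 2.4-fold lower number from compound 1 to compound 3 (0.39 log units; beyond the scatter). A small move towards a higher number in this assay is therefore expected, probably not beyond the scatter. The expected step is a 1.6-fold higher number from compound 3 to compound 4 (0.21 log units; within the scatter). For compound 4 the estimate is 65000 nM, with an expected range of 20000 nM to 150000 nM.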

Compound 4, half-maximal inhibitory concentration: 3900 nM
Compound 4: middle estimate off by 17-fold (1.22 log units), on the high side, and the stated range ends above it.
By their numbers in this assay, from the lowest: compound 4; then compounds 3 and 2 (each within the scatter of the next). At a limit, above all of these: compound 1.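

In this assay, among the compounds shown here, this position on the shared core can move the read-out much further than the earlier compounds showed: 2-phenylethenyl gives a 10-fold lower number from compound 3 to compound 4 (1.01 log units; beyond the scatter) and a 19-fold lower number from compound 2 to compound 4 (1.28 log units; beyond the scatter), while the methoxy step between the two compounds with a ring bonded directly to the core stayed within the scatter. An unsaturated link to the ring does not in itself set the level, as compound 1 also carries one and the reading is an at least 25-fold lower number from compound 1 to compound 4 (1.40 log units; beyond the scatter). The value of compound 1 is a limit, so that step is only a floor: the limit of > 100000 nM in this assay, at which 1 of the 4 values shown sits.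

Still open, from the compounds shown here alone, is whether the lower number follows the double bond or the phenyl ring at its end. A saturated 2-phenylethyl chain, a 2-phenylethynyl group and a 2-(thiophen-2-yl)ethenyl group would separate these readings.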